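A few compounds are considered here, and "the series" means these few. Any claim that something is new, unique, unknown or untested is made for them only; others in the source may bear on it.

Compound 1 `CC(C)N(Cc1cccc(OCCCCCC(=O)O)c1)C(=O)c1ccc(-c2ccc3cc[nH]c3c2)cc1`: in an ADME assay on HEK293 cells (Homo sapiens) for cytotoxicity, read by CellTiter-Glo and resazurin assay, with a stated time of 72 h (a higher number here means that more compound is needed for the effect, a lower number that less compound is needed), compound 1 gives > 26000 nM, which is a limit of the assay and not a number.
Compound 2 `CC(C)N(Cc1cccc(OCCCCCC(=O)O)c1)C(=O)c1ccc(-c2cccc(Br)c2)cc1`: in this assay compound 2 gives > 26000 nM, again a limit of the assay.

Among the measured compounds shown here, compound 2 therefore stands at the edge of what this assay reports: only a limit is known for it, and the one other value shown is a limit as well, as the limit of > 26000 nM in this assay, at which 2 of the 2 values shown sit, states. For the measured compounds named here, the single step between measured compounds, a step that the two limits leave unreadable from compound 1 to compound 2, cannot be read, since both ends are limits.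

Compound 3 `CC(C)N(Cc1cccc(OCCCCCC(=O)O)c1)C(=O)c1ccc(-c2cccc([N+](=O)[O-])c2)cc1` is not yet measured. It differs from compound 2 by nitro in place of bromo on an aromatic carbon, the same difference cut one bond further out reading 3-bromophenyl to 3-nitrophenyl. Going by the values given here, no measured step covers a change of this kind; the only step available, from compound 1 to compound 2, is unreadable and touches another part of the molecule. With both measured compounds sitting at the limit, no step beyond the scatter is expected in this assay. Compound 3 is accordingly estimated at 30000 nM, within 15000 nM to 60000 nM, and the step this implies, a step that the limit leaves unreadable from compound 2 to compound 3, is an expectation of no change beyond the scatter.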

Compound 3, half-maximal effective concentration: > 26000 nM
Compound 3: no number, only a limit; the forecaster's own chance of this, stated with the estimate: 85%; the middle value lies beyond the limit too.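

In this assay compound 3 gives > 26000 nM which is a limit of the assay and not a number. Among the compounds shown here, no step linking compound 3 with compound 1 or compound 2 can be read: the limit of > 26000 nM in this assay, at which 3 of the 3 values shown sit. The compounds shown leave open whether compound 1, compound 2 or compound 3 would reach a half-maximal effect in this assay at any higher concentration.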